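The source may report more compounds than this note shows. Statements on the series, on what has been measured and on what is new or still open speak of the compounds shown alone.

Compound 1 `Fc1cccc(-c2nc(Nc3ccccc3F)c3cc(F)ccc3n2)c1` gives in a functional assay on HT29-AK cells (Homo sapiens) for cytotoxicity, read by MTT assay, with a stated time of 48 h (on this read-out higher numbers stand for weaker inhibition and lower numbers for stronger inhibition), the value > 50000 nM, which is a limit of the assay.
Compound 2 `Fc1cccc(-c2nc(Nc3cccc(Br)c3)c3cc(F)ccc3n2)c1` gives in this assay the value > 50000 nM, likewise a limit.

Compound 2 therefore stands at the ceiling of the numbers shown, a position it shares with compound 1 (the limit of > 50000 nM in this assay, at which 2 of the 2 values shown sit). Among the compounds with values here, the single measured step, a step that the two limits leave unreadable from compound 1 to compound 2, runs between two limits and gives no readable size. Compound 3 `Oc1cccc(Nc2nc(-c3cccc(F)c3)nc3ccc(F)cc23)c1` is reached from compound 2 by hydroxy in place of bromo on an aromatic carbon. Within the data shown here, no measured step bears readably on this change, so no direction beyond the scatter can be expected in this assay. Compound 3 is estimated at 60000 nM, between 15000 nM and 250000 nM. The expected step is a step that the limit leaves unreadable from compound 2 to compound 3, most likely again a limit.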

Compound 3, half-maximal inhibitory concentration: > 50000 nM
Compound 3: only a limit was reported; the forecaster's own chance of this, stated with the estimate: 75%; the middle value lies beyond the limit too.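

No step among compound 1, compound 2 and compound 3 can be read, since each result is a limit: the limit of > 50000 nM in this assay, at which 3 of the 3 values shown sit.

Left open is whether the groups on the nitrogen differ at all in this assay, and at what concentration any of these compounds would inhibit.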